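Trading trifluoromethyl for methyl on compound 1

The source may hold more compounds than are shown below. What is called first, only, known or untested is meant among the compounds shown, and "the series" means these compounds.

Among the measured compounds shown here, in an ADME assay on Vero 76 cells (Chlorocebus sabaeus) for cytotoxicity, read by MTT assay, with a stated time of 96 h (a higher number here means that more compound is tolerated, a lower number that less compound is tolerated), compound 1 (`FC(F)(F)c1ccc(NCc2cn(-c3ccccc3)nc2-c2ccc(C(F)(F)F)cc2)cc1`) gives 26000 nM and so stands lowest of the two compounds measured so far. Compound 2 (`Clc1ccc(NCc2cn(-c3ccccc3)nc2-c2ccc(Cl)cc2)cc1`) reaches 90000 nM and the gap between them lies beyond the usual scatter. Compound 3 (`Cc1ccc(-c2nn(-c3ccccc3)cc2CNc2ccc(C(F)(F)F)cc2)cc1`) has not yet been measured. It keeps the core of compound 1 but carries methyl in place of trifluoromethyl on an aromatic carbon, para to a large group (methyl in place of trifluoromethyl on an aromatic carbon). The change turns a 4-(trifluoromethyl)phenyl into a 4-methylphenyl. For the measured compounds named here, no measured pair shows a single change of this kind, so the evidence is thin. Going by the values given here, the only guide is the pair of compound 1 at 26000 nM and compound 2 at 90000 nM, of which compound 2 stands the higher, in the same direction as the guess made here. A small upward step is expected a 1.7-fold higher number from compound 1 to compound 3 (0.24 log units; within the scatter) on this basis. Compound 3 is expected at 45000 nM with an estimated range of 18000 nM to 100000 nM for now.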

Compound 3, half-maximal cytotoxic concentration: 45000 nM
Compound 3: middle estimate and measured number agree at the digits printed, within the range that was stated.
By their numbers in this assay, from the lowest: compounds 1, 3 and 2 (each within the scatter of the next, the first and the last beyond it).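

Among the compounds shown here, this is the first comparison in which only one place changes: in this assay, putting methyl in place of trifluoromethyl on an aromatic carbon, para to a large group, gives a 1.7-fold higher number from compound 1 to compound 3 (0.24 log units; within the scatter). Losing three fluorine atoms here therefore produces no difference that can be told apart from repeat-measurement noise, so this single change does not account for the wider gap between compound 1 and compound 2. No measurement shown here offers an explanation for this result.

Compound 2 differs from compound 1 in two places, so the contribution of each place cannot be separated. On these data alone, it also remains open how this assay would respond to an amine, a carboxylic acid or a longer chain at this position.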